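The source may report more compounds than this note shows. Statements on the series, on what has been measured and on what is new or still open speak of the compounds shown alone.

Measured so far:
- compound 1 (`CCCCC(C#CC(=O)OC)O/C=C/C(=O)OC`) – 250 nM
- compound 2 (`CCCCCC(C#CC(=O)OC)O/C=C/C(=O)OC`) – 1900 nM
- compound 3 (`C#CC(O/C=C/C(=O)OC)c1ccccc1`) – 26000 nM

All three numbers come from a functional assay on HBL-100 cells (Homo sapiens) for antiproliferative activity, read by sulforhodamine B assay, with a stated time of 48 h; on this read-out higher numbers stand for weaker inhibition of growth and lower numbers for stronger inhibition of growth. Compound 1 has the lowest number of the three, and compound 3 has the highest. Compound 4 (`CCCC(C#CC(=O)OC)O/C=C/C(=O)OC`) has not yet been measured. The change to it is hydrogen in place of methyl on a saturated chain carbon, four bonds along the chain from an oxygen on an unsaturated carbon and a triple-bonded carbon; cut one bond further out, it reads butyl to propyl.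

Among the measured compounds shown here, only one measured step bears on this change: a 7.6-fold higher number from compound 1 to compound 2 (0.88 log units; beyond the scatter). That step puts methyl in place of hydrogen on the same chain, so it runs the opposite way to the change at hand. Compound 3 differs from compound 1 in more than one place and gives no guide here. A single step sets no trend, and a fall in the number cannot be excluded. Still, with compound 1 at 250 nM as the lowest of the three, a modest rise seems the likelier outcome, probably smaller than the measured step. The expected step is a 2.4-fold higher number from compound 1 to compound 4 (0.38 log units; beyond the scatter) in this read-out. For compound 4 the estimate is 600 nM, with an expected range of 120 nM to 3000 nM.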

Compound 4, concentration for 50% growth inhibition: 270 nM
Compound 4: middle estimate off by 2.2-fold (0.35 log units), on the high side; measured number inside the range.
By their numbers in this assay, from the lowest: compounds 1 and 4 (each within the scatter of the next); then compound 2; then compound 3.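

In this assay the change from butyl to propyl gives a 1.1-fold higher number from compound 1 to compound 4 (0.03 log units; within the scatter) and so leaves compounds 1 and 4 indistinguishable: at this position the methyl of the butyl chain can give way to hydrogen with no difference that the assay can resolve. Hydrogen in place of ethyl at the same place gives a 7.0-fold lower number from compound 2 to compound 4 (0.85 log units; beyond the scatter) and sets compound 4 clearly apart from compound 2, which, with a 7.6-fold higher number from compound 1 to compound 2 (0.88 log units; beyond the scatter) also beyond the scatter, shows that among these three chains the number does not follow chain length evenly: the two shorter chains sit together and only the longest separates. Nothing shown here gives a reason for this uneven response to chain length.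

From the compounds shown here alone, whether the shared level of compounds 1 and 4 holds for a still shorter chain, such as ethyl or methyl, or gives way at some point remains open. Also open, going by these compounds, is how a branched isopropyl group, a cyclopropyl group or a chain carrying an amine would read at this carbon on the core of compound 1.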